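The compounds below may be only part of what the source reports. "The series", "measured", "known", "first", "only" and "open" are said of these compounds alone.

Measured so far in a functional assay on U-251 cells (Homo sapiens) for antiproliferative activity, read by sulforhodamine B assay, with a stated time of 48 h, tested at 50 uM; on this read-out higher numbers stand for more inhibition at the one concentration tested (going by the name of the read-out) and lower numbers for less inhibition:

Compound 1 `Cc1cc2c(C(C)C)ccc(C)c2cc1OC(=O)c1cccc(C(F)(F)F)c1` gives "not active" (no number reported) in this assay.
Compound 2 `CC1=CC[C@H](C(C)C)c2cc(C)c(OC(=O)c3ccc([N+](=O)[O-])cc3)cc21` gives 16.8% in this assay.
Compound 3 `COc1ccc(C(=O)Oc2cc3c(C)ccc(C(C)C)c3cc2C)cc1` gives 42.6% in this assay.

Among the two compounds with a number, compound 2 stands lowest in this assay; compound 3 lies higher by a margin beyond the usual scatter, and compound 1 has no number at all. Compound 4 `CC1=CC[C@H](C(C)C)c2cc(C)c(OC(=O)c3cccc([N+](=O)[O-])c3)cc21` has not yet been measured. It keeps every atom of compound 2 and differs from it only in how they are joined: 3-nitrophenyl in place of 4-nitrophenyl on a carbonyl carbon. No pair of measured compounds differs in one place, so nothing shown says how large such a shift should be in this assay. A small step in either direction, or none beyond the scatter, is expected from compound 2 to compound 4 (a number 3.2 percentage points higher from compound 2 to compound 4 (within the scatter)). Compound 4 is therefore estimated at 20%, within a range from 5% to 40%.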

Compound 4, a percentage reported as inhibition, at one concentration (the size of the read-out at that concentration, not a potency): 44%
Beside the measured number, compound 4's estimate is 24 percentage points below it, outside the stated range (above it).
By their numbers in this assay, from the lowest: compound 2; then compounds 3 and 4 (each within the scatter of the next).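

In this assay, putting 3-nitrophenyl in place of 4-nitrophenyl on a carbonyl carbon gives a clear step (a number 27.2 percentage points higher from compound 2 to compound 4 (beyond the scatter)). Going by these compounds alone, the atoms stay the same and only their joining changes, so this position responds to how the group is attached, something the earlier compounds, with no pair differing in one place, could not show. Nothing measured here explains the shift. Still open, on these data alone, is how an amine or a carboxylic acid would fare in the same place, and whether the same swap gives a similar step on the core of compound 3.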